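This account rests on a few compounds, and the source may have more. Where it says the series, first, only, none or still open, it means among the compounds named here.

Measured so far in a functional assay on SW480 cells (Homo sapiens) for antiproliferative activity, read by MTT assay, with a stated time of 48 h; a higher number here means a weaker inhibitor, a lower number a stronger inhibitor:
- compound 1 `CCCCCCCC(CCO)n1cnc2c(N)nc(Cl)nc21`: > 50000 nM (a limit, not a number)
- compound 2 `CCCCCCCCCC(CCO)n1cnc2c(Cl)nc(Cl)nc21`: 36300 nM

For the measured compounds named here, compound 2 gives 36300 nM, the only true number in this small set. Compound 3 `CCCCCCCCCC(CCO)n1cnc2c(N)nc(Cl)nc21` is still unmeasured. It has amino in place of chloro on an aromatic carbon of compound 2, next to the ring nitrogen and ortho to a fused ring: amino in place of chloro on an aromatic carbon.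

Going by the values given here, no measured pair shows directly what this exchange does in this assay. Compound 1 also carries amino on that carbon, and compound 1 stays at > 50000 nM, which is a limit. The expected step of a 1.2-fold higher number from compound 2 to compound 3 (0.06 log units; within the scatter) is therefore small, within the scatter, with a slight lean towards a weaker inhibitor. For compound 3 the estimated value is 42000 nM, with an expected range from 18000 nM to 90000 nM.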

Compound 3, half-maximal inhibitory concentration: 12200 nM
For compound 3 the middle estimate is 3.4-fold (0.54 log units) above the measured one; the measured number lies below the stated range.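

In this assay, the direct comparison at this position shows that amino in place of chloro on an aromatic carbon, next to the ring nitrogen, gives a 3.0-fold lower number from compound 2 to compound 3 (0.47 log units; beyond the scatter), so here the exchange yields a stronger inhibitor. The chain matters as well: with amino kept on that carbon, ethyl in place of hydrogen on a saturated chain carbon, eight bonds along the chain from an aromatic nitrogen, gives an at least 4.0-fold lower number from compound 1 to compound 3 (0.61 log units; beyond the scatter). That second step is only a minimum, because compound 1 stands at a limit and not at a number: the limit of > 50000 nM in this assay, at which 1 of the 3 values shown sits.

As far as these compounds go, whether a methylamino or a hydroxyl group on the same aromatic carbon would lower the number further remains open. So does whether a longer chain would continue the trend seen from compound 1 to compound 3.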